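The source may hold more compounds than are shown below. What is called first, only, known or untested is meant among the compounds shown, and "the series" means these compounds.

Of the compounds shown here, two have been measured in an assay on CHO cells for inhibition of sodium channel protein type 2 subunit alpha (Homo sapiens); on this read-out lower numbers stand for stronger inhibition and higher numbers for weaker inhibition. Compound 1 `Cc1ccc(C(=O)NC(=N)Nc2ccc(C(C)C)cc2)cc1` gives 1950 nM in this assay. Compound 2 `N=C(NCCCCc1ccccc1)NC(=O)c1c(Cl)cccc1Cl` gives 5030 nM in this assay, the higher of the two numbers; its gap to compound 1 is beyond the usual scatter of repeated measurements, so compound 2 is the weaker inhibitor of the pair.

Compound 3 `N=C(NCCCCc1ccccc1)NC(=O)c1cccs1` has not yet been measured. It keeps the core of compound 2 and differs from it in one place: thiophen-2-yl in place of 2,6-dichlorophenyl on a carbonyl carbon. Among the compounds with values here, no two measured compounds differ by a change of this kind, so there is no measured step to lean on; compound 1 and compound 2 differ in more than one place, and their two values say nothing about this change on its own.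

With nothing else to go on, the expectation for compound 3 is set loosely around the value of compound 2. The step from compound 2 to compound 3 is expected to be a 1.4-fold higher number from compound 2 to compound 3 (0.14 log units; within the scatter), a slight weakening that may well sit within the scatter. Compound 3 is therefore expected to give about 7000 nM in this assay, with a range from 2500 nM to 20000 nM.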

Compound 3, half-maximal inhibitory concentration: 4310 nM
Compound 3: the middle estimate sits 1.6-fold (0.21 log units) above what was measured; the range from low to high includes it.
By their numbers in this assay, from the lowest: compound 1; then compounds 3 and 2 (each within the scatter of the next).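

Within the data shown here, the first measured step at this place, on a carbonyl carbon whose other neighbour is an amide-type nitrogen, comes out in this assay as a 1.2-fold lower number from compound 2 to compound 3 (0.07 log units; within the scatter). Swapping 2,6-dichlorophenyl, a six-membered carbon ring bearing chlorine atoms, for thiophen-2-yl, a five-membered aromatic ring with a sulfur atom and fewer heavy atoms, leaves two compounds that this read-out cannot tell apart, so for this pair neither the chlorine atoms nor the six-membered ring is needed to keep inhibition at this level. No measured property of either group accompanies these values, so the data offer no explanation for this result.

As far as these compounds go, both groups compared here are aromatic rings, so it remains open how this carbonyl carbon would respond to a group without a ring, such as a methyl or a longer alkyl chain, or to a ring carrying an amine or a carboxylic acid. From the compounds shown here alone, it is also open whether thiophen-2-yl would give a similarly flat result on the core of compound 1, which differs from compound 2 in more than one place.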